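A few compounds are considered here, and "the series" means these few. Any claim that something is new, unique, unknown or untested is made for them only; others in the source may bear on it.

Measured compounds in a functional assay on UO-31 cells (Homo sapiens) for cytotoxicity, read by sulforhodamine B assay, with a stated time of 48 h, tested at 0.01 uM; a lower number here means a stronger effect, a higher number a weaker effect of the compound at the concentration tested:

compound 1, `COc1ccc(-c2cc(/C=C/C(=O)c3ccc(N)cc3)[nH]n2)cc1`, gives 90%
compound 2, `COc1ccc(-c2cc(/C=C/C(=O)c3ccc(N)cc3)[nH]n2)cc1OC`, gives 92%
compound 3, `COc1cc(C(=O)/C=C/c2cc(-c3cc(OC)c(OC)c(OC)c3)n[nH]2)cc(OC)c1OC`, gives 90%

All three compounds share a chalcone-like arrangement with a pyrazole bearing a methoxy-substituted aryl group, and all three leave the cells at close to full growth at the concentration tested. Between compound 2 and compound 1 the only change is hydrogen in place of methoxy on an aromatic carbon, and the step is a number 2 percentage points lower from compound 2 to compound 1 (within the scatter). The difference between the core of compound 3 and the core of compound 2 is not broken down here; the values of compound 3 and compound 2 lie within the scatter of each other, and the value of compound 3 is level with that of compound 1 at the digits given.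

Compound 4, `COc1ccc(-c2cc(/C=C/C(=O)c3cc(OC)c(OC)c(OC)c3)[nH]n2)cc1OC`, is not yet measured. It differs from compound 3 by hydrogen in place of methoxy on an aromatic carbon, the same kind of change as that from compound 2 to compound 1, though here the place is also meta to a methoxy group, which is not the case in the earlier pair. Since that earlier change gave only a number 2 percentage points lower from compound 2 to compound 1 (within the scatter), the expected step is no change at the digits printed from compound 3 to compound 4 (within the scatter), resting on compound 3 and its value 90%. Compound 4 is therefore estimated at 90% in this assay, with a likely range from 80% to 100%.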

Compound 4, a percentage reported as activity, at one concentration (the size of the read-out at that concentration, not a potency): 88%
Estimate against measurement, compound 4: 2 percentage points above, and the stated range covers the measured number.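

In this assay, hydrogen in place of methoxy on an aromatic carbon gives a number 2 percentage points lower from compound 3 to compound 4 (within the scatter), and set beside the earlier step, the change carries over to the second core without a visible difference: the same change on two cores in this assay, a number 2 percentage points lower (within the scatter) from compound 2 to compound 1 and a number 2 percentage points lower (within the scatter) from compound 3 to compound 4, 0 percentage points apart, within the scatter of two such steps. This agreement is weak evidence of transfer, since both steps lie within the scatter and all four compounds leave the cells at close to full growth at the one concentration tested; the two cores thus agree only in showing no measurable effect of the change, and nothing here shows that the steps would still match where the compounds act strongly. The base is also narrow, with two pairs on two cores, and the place in the newer pair, meta to a methoxy group, has no match in the earlier pair.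

The compounds shown leave open what a hydroxy group, a chlorine atom or a carboxylic acid would do at this place on the aromatic ring. They also leave open whether removing methoxy has any effect on these cores at a higher concentration, where the read-out would have more room to move.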